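The compounds below may be only part of what the source reports. "The series", "measured", "known", "first", "only" and "open" are said of these compounds alone.

Measured in a functional assay on HOS-TE85 cells (Homo sapiens) for inhibition, read by CCK-8 assay, with a stated time of 72 h; on this read-out higher numbers stand for weaker inhibition and lower numbers for stronger inhibition:
- Compound 1 `CCN(CC)c1ccc(N2C(=O)CSC2c2cccc(C(=O)NCCCCc3ccccc3)c2)cc1` gives the limit > 1000 nM.
- Compound 2 `COc1ccccc1N1C(=O)CSC1c1cccc(C(=O)NCCCCn2cncn2)c1` gives the limit > 1000 nM.
- Compound 3 `CC(C)(C)c1conc1N1C(=O)CSC1c1cccc(C(=O)NCCCCc2ccccc2)c1` gives the limit > 1000 nM.

Compound 2 has no numerical value in this assay, only a limit, and the two other values are limits as well. The next compound to be measured is compound 4 `COc1ccccc1N1C(=O)CSC1c1cccc(C(=O)NCCCCn2ccc3ccccc32)c1`, which differs from compound 2 at the end of the chain: 1H-indol-1-yl in place of 1H-1,2,4-triazol-1-yl on a saturated chain carbon, four bonds along the chain from an amide-type nitrogen. The rest of the structure is unchanged.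

For the measured compounds named here, only one measured step exists, a step that the two limits leave unreadable from compound 1 to compound 3. It lies at a different place, on an amide-type nitrogen in a ring, and gives no size to carry over. Going by the values given here, no measured step covers a change on the saturated chain carbon. Among the compounds with values here, compound 4 is expected to stay where the series sits in this assay because the limit of > 1000 nM in this assay, at which 3 of the 3 values shown sit, is the only guide available. No step beyond the scatter is expected, and no direction can be assigned, although a readable number cannot be ruled out.

The estimated step is a step that the limit leaves unreadable from compound 2 to compound 4. For compound 4 the estimated value is 2000 nM, with an expected range from 400 nM to 10000 nM.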

Compound 4, half-maximal inhibitory concentration: 286 nM
Beside the measured number, compound 4's estimate is 7.0-fold (0.84 log units) above it; the measured number lies below the stated range.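

In this assay, for the compounds shown here, the end of the chain is the first place where a single change gives a readable step: 1H-indol-1-yl in place of 1H-1,2,4-triazol-1-yl, on a saturated chain carbon, four bonds along the chain from an amide-type nitrogen, gives an at least 3.4-fold lower number from compound 2 to compound 4 (0.54 log units; beyond the scatter) and so shows that this position can move the read-out. Going by these compounds alone, the entering group carries a six-membered aromatic ring of carbon only that the leaving group lacks, while the change on an amide-type nitrogen in a ring, from compound 1 to compound 3, cannot be read between its two limits. Compound 4 is so far the only number in the series, with the rest still resting on limits: the limit of > 1000 nM in this assay, at which 3 of the 4 values shown sit.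

One pair cannot separate the added carbon ring from the loss of hetero atoms in the five-membered ring, and a 1H-benzimidazol-1-yl or a plain phenyl group at the same place would bear on that question. Also open, from the compounds shown here alone, are whether a shorter or longer chain keeps the 1H-indol-1-yl group's step and whether the step holds with another group on the ring amide-type nitrogen, such as a 4-(diethylamino)phenyl group.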